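Trifluoromethyl to 1-methylethenyl on the indole aryl ring

A few compounds are considered here, and "the series" means these few. Any claim that something is new, unique, unknown or untested is made for them only; others in the source may bear on it.

Working notes on three measured compounds and one awaiting measurement in an assay on HEK293 cells for binding affinity to 5-hydroxytryptamine receptor 7 (Homo sapiens), read by radioligand binding, tested at 1 uM; on this read-out lower numbers stand for less inhibition and higher numbers for more inhibition at the one concentration tested (going by the name of the read-out). Compound 1 `CC1CN(CCn2ccc3ccc(Br)cc32)CCN1` gives 52% in this assay. Compound 2 `CC1CN(CCn2ccc3ccc(Br)cc32)CC(C)N1` gives 26%. Among the measured compounds shown here, the only single-point step among the measured compounds, a number 26 percentage points lower from compound 1 to compound 2 (beyond the scatter), concerns a saturated ring carbon of the amine ring and not the aromatic part of the core. Compound 3 `CN1CCCN(CCn2ccc3ccc(C(F)(F)F)cc32)CC1` gives 89%, the highest of the three numbers; its gap to compound 1 and its larger gap to compound 2 both lie beyond the scatter.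

Compound 4 `C=C(C)c1ccc2ccn(CCN3CCCN(C)CC3)c2c1` is the next compound to be measured. It differs from compound 3 by 1-methylethenyl in place of trifluoromethyl on an aromatic carbon. For the measured compounds named here, no measured step in the set touches this aromatic position or this kind of exchange, so nothing among the three compounds gives the size or direction of the change directly; the methyl step from compound 1 to compound 2 is of a different kind and is not taken as a guide here. Given that compound 3 sits high in this assay, compound 4 is expected to remain in the upper part of the range, with wide uncertainty: the estimate for compound 4 is 75%, between 50% and 92%, which corresponds to an expected step of a number 14 percentage points lower from compound 3 to compound 4 (beyond the scatter).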

Compound 4, a percentage reported as inhibition, at one concentration (the size of the read-out at that concentration, not a potency): 72%
For compound 4 the middle estimate is 3 percentage points above the measured one; low and high end bracket the measured number.
By their numbers in this assay, from the lowest: compound 2; then compound 1; then compound 4; then compound 3.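

In this assay, among the compounds shown here, the exchange of trifluoromethyl for 1-methylethenyl on the aromatic carbon gives a number 17 percentage points lower from compound 3 to compound 4 (beyond the scatter) and is the first step that reads this position directly, showing that the aromatic part of the core, and not only the saturated amine ring, can move the number. For the compounds shown here, the change is modest, and with 1-methylethenyl, which has three carbons and no fluorine, compound 4 still gives 72% in the same assay, so trifluoromethyl is not the only group on this carbon compatible with a substantial number at the one concentration tested. The data at hand offer nothing that bears on the reason for this step.

Still open, from the compounds shown here alone, is how a nitrile, a methoxy group or a primary amine on the same aromatic carbon would read in this assay with the amine ring and ethyl linker of compound 3 held constant. Also open, going by these compounds, is whether the exchange of trifluoromethyl for 1-methylethenyl would give a step of similar size and direction on the amine ring of compound 1, or with a propyl chain in place of the two-carbon link to the amine ring.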